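Moving a Chlorine Around the Ring on a Shared Core

The compounds below may be only part of what the source reports. "The series", "measured", "known", "first", "only" and "open" are said of these compounds alone.

Of the compounds shown here, two of this small series have been measured for how strongly they harm healthy skin fibroblast cells. Compound 1 `COc1ccccc1/C=C1\CCC/C(=C\c2cccc(OC)c2OC)C1=O` and compound 2 `COc1ccc(/C=C2\CCC/C(=C\c3ccccc3Cl)C2=O)cc1OC` share the same core and differ only in the groups hanging from it. In an ADME assay on NHDF cells (Homo sapiens) for cytotoxicity, read by MTT assay, with a stated time of 72 h (on this read-out higher numbers stand for weaker inhibition and lower numbers for stronger inhibition), compound 1 gives 31300 nM. In this assay compound 2 gives 21600 nM. These two numbers lie within the usual scatter of one another, so compound 2 does not stand apart from compound 1 on this read-out.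

Compound 3 `COc1ccc(/C=C2\CCC/C(=C\c3cccc(Cl)c3)C2=O)cc1OC` differs from compound 2 in one place: 3-chlorophenyl in place of 2-chlorophenyl on a double-bonded chain carbon bound to a double-bonded ring carbon. Going by the values given here, no measured pair here shows what such a move does, so nothing in the data points to a shift beyond the scatter. Compound 3 is therefore expected to give about 21000 nM, within a range from 8000 nM to 55000 nM. The expected step from compound 2 to compound 3 is a 1.0-fold lower number from compound 2 to compound 3 (0.01 log units; within the scatter), that is, none beyond the scatter.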

Compound 3, half-maximal inhibitory concentration: 11900 nM
The estimate for compound 3 lay 1.8-fold (0.25 log units) above the measured number, within the range that was stated.
By their numbers in this assay, from the lowest: compounds 3, 2 and 1 (each within the scatter of the next, the first and the last beyond it).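

Going by these compounds alone, this pair is the first to differ in one place only, so swapping 2-chlorophenyl for 3-chlorophenyl can be read on its own. In this assay the swap gives a 1.8-fold lower number from compound 2 to compound 3 (0.26 log units; within the scatter) and so stays inside the usual scatter of repeated measurements. The two groups hold the same atoms joined differently, so on a double-bonded chain carbon bound to a double-bonded ring carbon, this rearrangement does not clearly separate the two compounds, and no outside measurement is available to explain the size of the step.

The compounds shown leave open whether a different group at this place, such as an amine or a carboxylic acid, would give a step beyond the scatter. They also leave open whether the same swap would give a similar step on another core.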